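The compounds below may be only part of what the source reports. "The series", "measured", "known", "first", "only" and "open" are said of these compounds alone.

Compound 1, `COc1ccc(-n2nc(-c3ccccc3)nc2CNc2ccc(C(=O)NO)cc2)cc1`, was examined in an assay on Sf9 cells for inhibition of protein deacetylase HDAC6 (Homo sapiens), read by fluorescence, with a stated time of 40 min, tested at 100 nM (on this read-out higher numbers stand for more inhibition at the one concentration tested (going by the name of the read-out) and lower numbers for less inhibition), where compound 1 gives 63.4%. Compound 2, `O=C(NO)c1ccc(NCc2nc(-c3cccnc3)nn2-c2ccccc2)cc1`, was tested in this assay, and compound 2 gives 57.7%. On the two numbers shown, compound 2 sits alongside compound 1, the two values lying within the scatter of each other, so neither compound can be set apart from the other on this read-out.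

Compound 3, `Cc1cccc(-c2nc(CNc3ccc(C(=O)NO)cc3)n(-c3ccccc3)n2)c1`, has not yet been measured in this assay. It differs from compound 2 in one place: 3-methylphenyl in place of pyridin-3-yl on an aromatic carbon. Going by the values given here, no measured pair shows this exact change, so its effect is unknown from the data at hand. Compound 1, which carries a phenyl at the same position, gives 63.4%, and compound 2 gives 57.7%, so the replacement of one six-membered aromatic ring by another at this site has so far moved the number by no more than the scatter.

For compound 3 the expected step of a number 4.3 percentage points higher from compound 2 to compound 3 (within the scatter) is therefore small and, if anything, upward, but not beyond the scatter. Compound 3 is estimated to give 62%, within a range from 48% to 76%.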

Compound 3, a percentage reported as inhibition, at one concentration (the size of the read-out at that concentration, not a potency): 64.1%
Estimate against measurement, compound 3: 2.1 percentage points below; the measured number falls inside the stated range.
By their numbers in this assay, from the lowest: compounds 2, 1 and 3 (each within the scatter of the next).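

In this assay, going by these compounds alone, putting 3-methylphenyl in place of pyridin-3-yl on the aromatic carbon of the five-membered ring gives a number 6.4 percentage points higher from compound 2 to compound 3 (within the scatter), and this is the only measured pair that isolates this exchange at this position. It shows that, on this carbon, the ring nitrogen of pyridin-3-yl can be absent and a methyl group present on a ring of carbon only, with the read-out still unable to set compound 3 apart from compound 2. No further information is at hand that bears on this result.

The pair leaves open what the ring nitrogen and the methyl group each contribute, as the two enter and leave together in this one step, and a value at a single concentration cannot show whether compound 2 and compound 3 would stay together across a range of concentrations. It also leaves open whether a group of another kind on this carbon, such as an amine, a carboxylic acid or a longer chain in place of the six-membered aromatic ring, would stay within the scatter of compound 2.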